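The source may report more compounds than this note shows. Statements on the series, on what has been measured and on what is new or still open speak of the compounds shown alone.

Measured in an ADME assay on a cell-free system (plasma, Rattus norvegicus) for metabolic stability, read by LC-MS, with a stated time of 60 min, tested at 100 uM; a higher number here means that more of the compound is left, a lower number that less of the compound is left:
- compound 1 `Cc1c(OCCCCOc2ccc(C(=O)O)cc2F)ccc(C(=O)CC2CCCC2)c1O`: 97%
- compound 2 `Cc1cc(C(=O)O)ccc1OCCCCOc1ccc(C(=O)CC2CCCC2)c(O)c1C`: 99%

Compound 2 stands level with compound 1 within the scatter. Going by the values given here, the only measured step is a number 2 percentage points higher from compound 1 to compound 2 (within the scatter), with methyl in place of fluoro on an aromatic carbon. Compound 3 `Cc1cc(OCCCCOc2ccc(C(=O)CC3CCCC3)c(O)c2C)ccc1C(=O)O` has the same atoms as compound 2, joined differently: 4-carboxy-3-methylphenyl in place of 4-carboxy-2-methylphenyl on an oxygen on a saturated carbon. The measured step is the only one that bears on this change, and it offers a loose guide at best. Expected in this assay is no step beyond the scatter, and the estimate is a number 2 percentage points lower from compound 2 to compound 3 (within the scatter). Compound 3 is expected at 97%, with an estimated range of 88% to 100%.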

Compound 3, percent of the compound remaining: 114%
Compound 3: middle estimate off by 17 percentage points, on the low side, and the stated range ends below it.
By their numbers in this assay, from the lowest: compounds 1 and 2 (each within the scatter of the next); then compound 3.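

In this assay, 4-carboxy-3-methylphenyl in place of 4-carboxy-2-methylphenyl on an oxygen on a saturated carbon gives a number 15 percentage points higher from compound 2 to compound 3 (beyond the scatter) with no change in atom count, whereas methyl in place of fluoro stayed within the scatter. The same group in place of 4-carboxy-2-fluorophenyl gives a number 17 percentage points higher from compound 1 to compound 3 (beyond the scatter) as a second step beyond the scatter, so this rearrangement of the ring substituents registers where the earlier exchange did not. Nothing available explains the rise. As far as these compounds go, whether it carries over to 4-carboxy-3-fluorophenyl remains open, as does its fate with a tetrazole in place of the carboxylic acid.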